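A few compounds are considered here, and "the series" means these few. Any claim that something is new, unique, unknown or untested is made for them only; others in the source may bear on it.

- compound 1 `C=C1C[C@@H](O)/C=C(\C)CC[C@@H](C(C)C)[C@@H](O)C1` with >= 10 ug/mL as a limit
- compound 2 `C=C1C[C@@H](O)/C=C(\C)CC[C@@H](C(C)C)[C@@H](O)[C@@H]1O` with >= 10 ug/mL as a limit

In an ADME assay on cells (Macrophage, Mus musculus) for cytotoxicity, read by MTT assay, with a stated time of 24 h (a lower number here means a stronger inhibitor, a higher number a weaker inhibitor), compound 2 gives >= 10 ug/mL as a limit and not a number. Within the data shown here, the one measured step is a step that the two limits leave unreadable from compound 1 to compound 2 and gives no size to carry over, and the series so far offers only the limit of >= 10 ug/mL in this assay, at which 2 of the 2 values shown sit, as evidence. Compound 3 `C=C1C[C@@H](OC(C)=O)/C=C(\C)CC[C@@H](C(C)C)[C@@H](O)[C@@H]1O` carries acetyl in place of hydrogen on an oxygen on a saturated carbon in the change hydroxy to acetoxy. Among the measured compounds shown here, no measured step covers this change, so no direction can be expected, and a result close to the limit of compound 2 is the plainest expectation. The expected move is a step that the limit leaves unreadable from compound 2 to compound 3 and no firmer claim can be made. For compound 3 the estimated value is 12 ug/mL with an expected range of 5 ug/mL to 30 ug/mL in this series.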

Compound 3, half-maximal inhibitory concentration: >= 10 ug/mL
Compound 3 was reported as a limit; the forecaster's own chance of this, stated with the estimate: 60%; the middle value lies beyond the limit too.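

In this assay, among these compounds, compound 3 gives >= 10 ug/mL, a limit and not a number, so no step from compound 2 to compound 3 can be read. The compounds shown leave open whether hydroxy to acetoxy shifts cytotoxicity at all.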